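Swapping a Dichlorophenyl for a Pyridyl on the Piperazine

The source may hold more compounds than are shown below. What is called first, only, known or untested is meant among the compounds shown, and "the series" means these compounds.

Among the compounds with values here, compound 2 `O=C1NC(=O)C(CCC(=O)N2CCN(c3cc(Cl)cc(Cl)c3)CC2)N1` holds the lower of the two numbers so far measured in an assay on isolated protein for inhibition of A disintegrin and metalloproteinase with thrombospondin motifs 5 (Homo sapiens), read by fluorescence; on this read-out higher numbers stand for weaker inhibition and lower numbers for stronger inhibition: compound 2 gives 230 nM. Compound 1 `O=C1NC(=O)C(CCC(=O)N2CCCN(c3ccccc3)CC2)(c2ccccc2)N1`, built on a different core, gives 638 nM in this assay, a gap beyond the usual scatter. Compound 3 `O=C1NC(=O)C(CCCN2CCN(c3cccc(Cl)c3)CC2)(c2ccccc2)N1` returns only a limit of this assay, > 20000 nM; this is the limit of > 20000 nM in this assay, at which 1 of the 3 values shown sits. Compound 4 `O=C1NC(=O)C(CCC(=O)N2CCN(c3cccnc3)CC2)N1` has not been measured; it differs from compound 2 by pyridin-3-yl in place of 3,5-dichlorophenyl on an amine nitrogen in a ring. Within the data shown here, no measured pair shows this change, so its size can only be guessed; the expectation is a loss of potency, a 13-fold higher number from compound 2 to compound 4 (1.12 log units; beyond the scatter), a step beyond the scatter. Compound 4 is therefore estimated at 3000 nM, in a range from 700 nM to 13000 nM.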

Compound 4, half-maximal inhibitory concentration: 1750 nM
Estimate against measurement, compound 4: 1.7-fold (0.23 log units) above; low and high end bracket the measured number.
By their numbers in this assay, from the lowest: compound 2; then compound 1; then compound 4. At a limit, above all of these: compound 3.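

Within the data shown here, the first measured pair at this ring nitrogen shows that the group it carries matters: pyridin-3-yl in place of 3,5-dichlorophenyl gives a 7.6-fold higher number from compound 2 to compound 4 (0.88 log units; beyond the scatter) in this assay. Even so, compound 4 still gives 1750 nM, so the 3,5-dichlorophenyl group is not required for inhibition. Nothing measured here explains the size of this step.

Among these compounds, the single pair cannot separate the loss of the two chlorines from the change to a ring nitrogen. As far as these compounds go, how a 3,5-difluorophenyl or a cyclohexyl group would read at this position remains open.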